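Adding a Second Chloro to Compound 3

The source may hold more compounds than are shown below. What is called first, only, known or untested is meant among the compounds shown, and "the series" means these compounds.

Measured so far in a functional assay on NCI-H226 cells (Homo sapiens) for cytotoxicity, read by sulforhodamine B assay, with a stated time of 48 h; a lower number here means that less compound is tolerated, a higher number that more compound is tolerated:
compound 1, `ClCc1ccccc1Cn1cnc2ncnc(Cl)c21`: > 100000 nM (a limit of the assay, not a number)
compound 2, `ClCc1ccccc1Cn1cnc2c(Cl)nc(Cl)nc21`: 6760 nM
compound 3, `ClCc1ccc(Cn2cnc3ncnc(Cl)c32)cc1`: 37200 nM

From the compounds shown here alone, compound 1 gives only a limit in this assay, (the limit of > 100000 nM in this assay, at which 1 of the 3 values shown sits), so its true value is unknown. Among the two real numbers, compound 3 stands highest; compound 2 sits lower, by a gap that lies beyond the usual scatter of repeated measurements. Compound 3 and compound 2 differ in where the chloromethyl group sits on the benzyl ring and in the number of chloro groups on the shared core.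

The unmeasured compound 4, `ClCc1ccc(Cn2cnc3nc(Cl)nc(Cl)c32)cc1`, is made from compound 3 by one change: chloro in place of hydrogen on an aromatic carbon. Within the data shown here, no measured pair shows this exact step, so its size can only be guessed. The two-chloro pattern of compound 2 goes with a lower number than the one-chloro pattern of compound 3, which points the expectation downward. For compound 4 a step of a 7.4-fold lower number from compound 3 to compound 4 (0.87 log units; beyond the scatter) is expected in this assay, that is, a clearly lower number. Compound 4 is therefore estimated at 5000 nM, with a likely range from 1500 nM to 20000 nM.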

Compound 4, concentration lethal to 50% of the cells: 15500 nM
The estimate for compound 4 lay 3.1-fold (0.49 log units) below the measured number; measured number inside the range.
By their numbers in this assay, from the lowest: compound 2; then compound 4; then compound 3. At a limit, above all of these: compound 1.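

In this assay, chloro in place of hydrogen on an aromatic carbon, between two ring nitrogen atoms, now has a direct reading, a 2.4-fold lower number from compound 3 to compound 4 (0.38 log units; beyond the scatter), a modest move toward less compound being tolerated. The same change also links compound 1 to compound 2, but compound 1 gives only a limit, > 100000 nM, so that step cannot be read. Nothing at hand explains the size of the step from the structures.

From the compounds shown here alone, whether chloro is special at this place stays open, since an amine, a methoxy group or a longer chain there could leave the number higher or lower. Also open, going by these compounds, is whether the step keeps its size in other compounds, as a single readable pair cannot show a general trend.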